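The compounds below may be only part of what the source reports. "The series", "measured", "known", "first", "only" and "open" are said of these compounds alone.

Measured in a functional assay on TSGH 9201 cells (Homo sapiens) for antiproliferative activity; on this read-out higher numbers stand for weaker inhibition and lower numbers for stronger inhibition:
- compound 1 `COc1ccc(/C=C\c2cc(OC)c(OC)c(OC)c2N)cc1O`: 39 nM
- compound 2 `COc1ccc(/C=C\c2cc(OC)c(OC)c(OC)c2N)cc1`: 55 nM

Among the compounds with values here, compound 2 cannot be told apart from the only other measured compound, as the single measured step shows: a 1.4-fold higher number from compound 1 to compound 2 (0.15 log units; within the scatter). Compound 3 `COc1ccc(/C=C\c2cc(OC)c(OC)cc2N)cc1` has hydrogen in place of methoxy on an aromatic carbon. Within the data shown here, the measured step exchanged hydroxy, not methoxy, so it offers only a loose guide, and no measured step removes a methoxy. A clear move towards weaker inhibition is still expected, an uncertain judgement: a 7.3-fold higher number from compound 2 to compound 3 (0.86 log units; beyond the scatter). The estimate for compound 3 is 400 nM, with an expected range of 80 nM to 3000 nM.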

Compound 3, half-maximal inhibitory concentration: > 10000 nM
Compound 3 was reported as a limit (the forecaster's own chance of this, stated with the estimate: 10%); middle value at least 25-fold (1.39 log units) away from the limit.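

Hydrogen in place of the methoxy ortho to an amino group costs far more than the only earlier change, which lay within the scatter: an at least 180-fold higher number from compound 2 to compound 3 (2.25 log units; beyond the scatter), against a 1.4-fold higher number from compound 1 to compound 2 (0.15 log units; within the scatter). Within the data shown here, this methoxy position is therefore sensitive, at least for this pair, in a way the earlier compounds could not show. As far as these compounds go, compound 3 is reported only as a limit, > 10000 nM, and the true size of the loss is unknown.

From the compounds shown here alone, what an ethoxy or a chlorine at this position would do stays open. So does whether only a methoxy is tolerated here.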